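The source may report more compounds than this note shows. Statements on the series, on what has been measured and on what is new or still open speak of the compounds shown alone.

Compound 1 `CCOc1ccc(CN(Cc2ccc(C(C)(C)C)cc2)Cc2cc3cc(C)ccc3[nH]c2=O)cc1` — in a toxicity assay on MDCK cells (Canis lupus familiaris) for cytotoxicity, read by crystal violet staining, with a stated time of 48 h (on this read-out higher numbers stand for lower toxicity in this test and lower numbers for higher toxicity in this test), compound 1 gives > 10000 nM, which is a limit of the assay and not a number.
Compound 2 `CCCOc1ccc(CN(Cc2ccc(C(C)(C)C)cc2)Cc2cc3cc(C)ccc3[nH]c2=O)cc1` — in this assay compound 2 gives > 5000 nM, again a limit rather than a number.
Compound 3 `Cc1ccc2[nH]c(=O)c(CN(Cc3ccc(C(C)(C)C)cc3)[C@@H](C)c3ccc(F)cc3)cc2c1` — in this assay compound 3 gives > 5000 nM, also a limit and not a number.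

All three measured compounds share one core and differ only in the groups carried on the amine nitrogen. From compound 1 to compound 2 the change is methyl in place of hydrogen on a saturated chain carbon, two bonds along the chain from an oxygen on an aromatic ring, and the step in this assay is a step that the two limits leave unreadable from compound 1 to compound 2. From compound 1 to compound 3 the change is 1-(4-fluorophenyl)ethyl in place of 4-ethoxybenzyl on an amine nitrogen, with the step that the two limits leave unreadable from compound 1 to compound 3; from compound 2 to compound 3 the step is a step that the two limits leave unreadable from compound 2 to compound 3. None of the three steps can be read, since every value sits at a limit: the limit of > 10000 nM in this assay, at which 1 of the 3 values shown sits, and (the limit of > 5000 nM in this assay, at which 2 of the 3 values shown sit).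

Compound 4 `CCc1ccc2[nH]c(=O)c(CN(Cc3ccc(C(C)(C)C)cc3)[C@@H](C)c3ccc(F)cc3)cc2c1` has not yet been measured in this assay. It differs from compound 3 by methyl in place of hydrogen on a saturated chain carbon bound to an aromatic carbon. Among the measured compounds shown here, this is the same kind of change as the one from compound 1 to compound 2, though the place is not the same: there the methyl enters on a saturated chain carbon two bonds along the chain from an oxygen on an aromatic ring, here on a saturated chain carbon bound to an aromatic carbon. The two cores differ as described for compound 1 and compound 3.

Since the earlier step of this kind left no readable size, and all three measured compounds sit at limits, compound 4 is expected to show the step that the limit leaves unreadable from compound 3 to compound 4 in this assay and, most likely, to be reported as a limit once more. The estimate for compound 4 in this assay is 8000 nM, with a range from 4000 nM to 20000 nM.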

Compound 4, half-maximal cytotoxic concentration: > 5000 nM
Compound 4 ended at the assay's limit; the forecaster's own chance of this, stated with the estimate: 80%; the middle value is on the limit's open side.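

The step from compound 3 to compound 4 cannot be read, since both compounds give a limit of the assay and not a number in this assay: the limit of > 5000 nM in this assay, at which 3 of the 4 values shown sit.

The compounds shown leave open where the half-maximal cytotoxic concentration of any of them actually lies in this assay, and whether methyl in place of hydrogen changes it at either place.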